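The source may hold more compounds than are shown below. What is called first, only, known or untested is meant among the compounds shown, and "the series" means these compounds.

Measured so far in a functional assay on DU-145 cells (Homo sapiens) for inhibition, read by MTT assay, with a stated time of 48 h; on this read-out higher numbers stand for weaker inhibition and lower numbers for stronger inhibition:
- compound 1 `CS(=O)(=O)Nc1ccc(-n2cc(COc3ccccc3Cl)nn2)cc1Oc1ccccc1` gives 21100 nM
- compound 2 `CS(=O)(=O)Nc1ccc(-n2cc(-c3ccccc3)nn2)cc1Oc1ccccc1` gives 14200 nM
- compound 3 `Cc1cc(OCc2cn(-c3ccc(NS(C)(=O)=O)c(Oc4ccccc4)c3)nn2)ccc1Cl` gives 5900 nM

Compound 3 has the lowest number of the three, and so the strongest inhibition here. Its gaps to the other two lie beyond the scatter, as a 2.4-fold lower number from compound 2 to compound 3 (0.38 log units; beyond the scatter) and a 3.6-fold lower number from compound 1 to compound 3 (0.55 log units; beyond the scatter) show.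

The next compound is compound 4 `Cc1ccc(-c2cn(-c3ccc(NS(C)(=O)=O)c(Oc4ccccc4)c3)nn2)cc1`, which differs from compound 3 as follows: 4-methylphenyl in place of (4-chloro-3-methylphenoxy)methyl on an aromatic carbon. In words, 4-methylphenyl comes in place of (4-chloro-3-methylphenoxy)methyl on an aromatic carbon.

Compound 2 is the closest guide, since it carries phenyl on that same carbon. The step of a 2.4-fold lower number from compound 2 to compound 3 (0.38 log units; beyond the scatter) therefore suggests that this change, run in the opposite direction, could cost a similar modest amount. The step of a 1.5-fold lower number from compound 1 to compound 2 (0.17 log units; within the scatter) is a caution: there, a swap to phenyl moved the number by no more than the scatter. Compound 1, however, starts from a much higher number than compound 3. Among the measured compounds shown here, no measured compound shows what the added methyl does.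

The expected change is a 2.2-fold higher number from compound 3 to compound 4 (0.34 log units; beyond the scatter), towards weaker inhibition in this assay. The estimated value for compound 4 is 13000 nM, with an expected range from 5500 nM to 30000 nM.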

Compound 4, half-maximal inhibitory concentration: 11200 nM
Estimate against measurement, compound 4: 1.2-fold (0.06 log units) above, and the stated range covers the measured number.
By their numbers in this assay, from the lowest: compounds 3, 4, 2 and 1 (each within the scatter of the next, the first and the last beyond it).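

In this assay, the swap of the (4-chloro-3-methylphenoxy)methyl group for 4-methylphenyl gives a step that can't be read as a real change (a 1.9-fold higher number from compound 3 to compound 4 (0.28 log units; within the scatter)), and the same holds for the swap from the (2-chlorophenoxy)methyl group (a 1.9-fold lower number from compound 1 to compound 4 (0.28 log units; within the scatter)), even though compound 1 and compound 3 differ from each other beyond the scatter. Among the compounds shown here, the one change that adds only a methyl, in place of hydrogen on the phenyl group, is also too small to read (a 1.3-fold lower number from compound 2 to compound 4 (0.10 log units; within the scatter)), so this methyl has no measurable effect on the number in this assay. No outside measurement is available that would explain any of these steps.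

Every group shown on this carbon carries a six-membered aromatic ring of carbon only, so it remains open how the number would respond to a group without such a ring, such as an aminomethyl group, a carboxylic acid or a longer alkyl chain. It is also unclear whether the chlorine or the methyl of the 4-chloro-3-methylphenyl group accounts for the gap between compound 1 and compound 3, since these two compounds differ in both at once.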